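A few compounds are considered here, and "the series" means these few. Any claim that something is new, unique, unknown or untested is made for them only; others in the source may bear on it.

Measured so far in an ADME assay for permeability, using PAMPA, at pH 7.4; a higher number here means that the compound crosses the layer faster, a lower number that the compound crosses the layer more slowly:
compound 1, `Cc1cc(NC(=O)Nc2ccc(C)c(Cl)c2)c2ccccc2n1`: 262 10^-6 cm/s
compound 2, `Cc1ccc(NC(=O)Nc2cc(C)nc3ccccc23)cc1`: 669 10^-6 cm/s
compound 3, `Cc1cc(NC(=O)Nc2ccccc2F)c2ccccc2n1`: 817 10^-6 cm/s

Compound 2 holds the second highest of the three numbers in this assay. Its nearest neighbour is compound 3, and the step of a 1.2-fold higher number from compound 2 to compound 3 (0.09 log units; within the scatter) stays within the scatter, so the two cannot be ordered. Its furthest neighbour is compound 1, and the step of a 2.6-fold higher number from compound 1 to compound 2 (0.41 log units; beyond the scatter) lies beyond the scatter.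

Compound 4, `CSc1ccc(NC(=O)Nc2cc(C)nc3ccccc23)cc1`, is not yet measured. It differs from compound 2 in one place: methylsulfanyl in place of methyl on an aromatic carbon. Among the measured compounds shown here, no measured step shows this exchange. The step of a 2.6-fold higher number from compound 1 to compound 2 (0.41 log units; beyond the scatter) concerns another substituent change and was modest; the step of a 1.2-fold higher number from compound 2 to compound 3 (0.09 log units; within the scatter) replaced the whole 4-methylphenyl group and still stayed within the scatter. Both measured compounds of the shared core with an intact 4-methylphenyl or 2-fluorophenyl sit in the same high region, and nothing among the three suggests that a methylsulfanyl would shift the number strongly. The step from compound 2 to compound 4 is therefore expected to be a 1.1-fold lower number from compound 2 to compound 4 (0.05 log units; within the scatter), not beyond the scatter, if anything slightly downward. Compound 4 is estimated to give 600 10^-6 cm/s in this assay, with a range from 330 10^-6 cm/s to 1100 10^-6 cm/s.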

Compound 4, apparent permeability: 473 10^-6 cm/s
Estimate against measurement, compound 4: 1.3-fold (0.10 log units) above, within the range that was stated.
By their numbers in this assay, from the lowest: compounds 1, 4, 2 and 3 (each within the scatter of the next, the first and the last beyond it).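

Methylsulfanyl in place of methyl on an aromatic carbon, para to a large group, gives a 1.4-fold lower number from compound 2 to compound 4 (0.15 log units; within the scatter) in this assay and so stays within the scatter. Unlike the earlier steps, this one keeps the 4-substituted phenyl group in place and changes only the substituent at this position, so the entering sulfur and hydrogen-bond acceptor, absent from methyl, come with no reading separable from compound 2 in this assay. Nothing in the data at hand speaks to the origin of this reading.

From the compounds shown here alone, whether a group of a different kind at this aromatic carbon, such as an amine, a carboxylic acid or a longer chain like butylsulfanyl, would also remain within the scatter of compound 2 stays open. Among the compounds shown here, also open is whether the same exchange of methyl for methylsulfanyl would read the same with the chloro group of compound 1 on the ring, since the one step at this position comes from a ring that carries no chloro.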